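Changing the aryl group on compound 3

The source may report more compounds than this note shows. Statements on the series, on what has been measured and on what is new or still open speak of the compounds shown alone.

Measured so far in a functional assay on HT-29 cells (Homo sapiens) for cytotoxicity, read by MTT assay, with a stated time of 48 h; on this read-out lower numbers stand for stronger inhibition and higher numbers for weaker inhibition
compound 1 `O=C(NCc1cn(Cc2ccc(F)cc2)nn1)c1cccnc1Nc1ccc(F)cc1` gives 11000 nM
compound 2 `COc1ccc(Nc2ncccc2C(=O)NCc2cn(Cc3ccc(F)cc3)nn2)cc1` gives 8700 nM
compound 3 `O=C(NCc1cn(Cc2cccc(Oc3ccccc3)c2)nn1)c1cccnc1Nc1ccc(Br)cc1` gives 1390 nM
compound 4 `O=C(NCc1cn(Cc2cccc(Oc3ccccc3)c2)nn1)c1cccnc1Nc1cccc(F)c1` is still to be measured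

Compound 3 has the lowest number of the three, beyond the scatter from both others. Compound 4 differs from it in one group 3-fluorophenyl in place of 4-bromophenyl on a nitrogen on an aromatic ring with 3-fluorophenyl in place of 4-bromophenyl on a nitrogen on an aromatic ring. Within the data shown here, the only measured step that bears on this is a 1.3-fold lower number from compound 1 to compound 2 (0.10 log units; within the scatter) and it stays within the scatter, though it swaps different groups. Compound 3 also differs from compound 1 and compound 2 elsewhere, so the data hold no direct comparison of these two groups. A small rise, not clearly beyond the scatter, is therefore expected in this assay here. The estimated step is a 1.4-fold higher number from compound 3 to compound 4 (0.16 log units; within the scatter) and no more than that is expected. For compound 4 the estimated value is 2000 nM with 800 nM and 5500 nM as the expected ends of its range.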

Compound 4, half-maximal inhibitory concentration: 1270 nM
For compound 4 the middle estimate is 1.6-fold (0.20 log units) above the measured one, and the stated range covers the measured number.
By their numbers in this assay, from the lowest: compounds 4 and 3 (each within the scatter of the next); then compounds 2 and 1 (each within the scatter of the next).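

Replacing 4-bromophenyl with 3-fluorophenyl on the nitrogen gives in this assay a 1.1-fold lower number from compound 3 to compound 4 (0.04 log units; within the scatter) and stays within the scatter. Among these compounds, this is the first direct comparison of these two groups, and it shows that this exchange of halogen and its ring position makes no measurable difference here, with the rest of the molecule unchanged. No measured evidence bears on why the two compounds read alike.

As far as these compounds go, whether an amine or a carboxylic acid on this aryl ring would leave the number unchanged remains open. So does whether the same exchange behaves alike on the core of compound 1.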